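Chain variation on the ring nitrogen: toward compound 4

The compounds below may be only part of what the source reports. "The series", "measured", "known", "first", "only" and "open" are said of these compounds alone.

Working notes on the shared core with a varied chain on the nitrogen on an aromatic ring. In an ADME assay on MT4 cells (Homo sapiens) for cytotoxicity, read by MTT assay, with a stated time of 5 days (a lower number here means that less compound is tolerated, a higher number that more compound is tolerated), compound 1 `CCCCN(c1ccnc(Nc2ccc(C#N)cc2)n1)c1c(F)cc(-c2ccc(C#N)cc2)cc1F` gives 211000 nM. In this assay compound 2 `CCC(C)N(c1ccnc(Nc2ccc(C#N)cc2)n1)c1c(F)cc(-c2ccc(C#N)cc2)cc1F` gives 217000 nM. For compound 3 `CCC(C)CN(c1ccnc(Nc2ccc(C#N)cc2)n1)c1c(F)cc(-c2ccc(C#N)cc2)cc1F` only a limit is known in this assay, namely > 255000 nM; this is a limit of the assay and not a number, so compound 3 stands at the limit of > 255000 nM in this assay, at which 1 of the 3 values shown sits. Among the measured steps, a 1.0-fold higher number from compound 1 to compound 2 (0.01 log units; within the scatter), an at least 1.2-fold higher number from compound 1 to compound 3 (0.08 log units; that floor lies within the scatter) and an at least 1.1-fold higher number from compound 2 to compound 3 (0.07 log units; that floor lies within the scatter) all lie within the scatter: nothing in this set moves the read-out beyond it.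

Compound 4 `C=CCN(c1ccnc(Nc2ccc(C#N)cc2)n1)c1c(F)cc(-c2ccc(C#N)cc2)cc1F` is the next member. Relative to compound 3 the change is vinyl in place of sec-butyl on a saturated chain carbon bound to a nitrogen on an aromatic ring; cut one bond further out, the same difference reads 2-methylbutyl to allyl. The three measured steps all concern changes of this chain on the same nitrogen and all stayed within the scatter, so the step into compound 4 in this assay is expected to stay within the scatter too, in no particular direction.

Compound 4 is therefore estimated to give 220000 nM in this assay, with a range from 130000 nM to 270000 nM. The estimate means a step of an at least 1.1-fold lower number from compound 3 to compound 4 (0.06 log units; that floor lies within the scatter), expected to remain within the scatter, with a fair chance that only a limit is again reported.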

Compound 4, half-maximal cytotoxic concentration: 249000 nM
The estimate for compound 4 lay 1.1-fold (0.05 log units) below the measured number; measured number inside the range.
By their numbers in this assay, from the lowest: compounds 1, 2 and 4 (each within the scatter of the next). At a limit, above all of these: compound 3.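

In this assay allyl, a chain with a double bond outside aromatic rings, gives a number in line with the saturated chains on this nitrogen, with a 1.2-fold higher number from compound 1 to compound 4 (0.07 log units; within the scatter) and a 1.1-fold higher number from compound 2 to compound 4 (0.06 log units; within the scatter) both lying within the scatter. Across butyl, sec-butyl, 2-methylbutyl and allyl, no step shown at this position leaves the scatter, so the flat picture seen for the saturated chains now also covers a chain ending in vinyl. The comparison with 2-methylbutyl gives only a floor, an at least 1.0-fold lower number from compound 3 to compound 4 (0.01 log units; that floor lies within the scatter) and its starting point is a limit of the assay and not a number: the limit of > 255000 nM in this assay, at which 1 of the 4 values shown sits.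

As far as these compounds go, it remains open whether a chain carrying an amine or a carboxylic acid, or a chain longer than butyl, on this nitrogen would move the read-out beyond the scatter. Also open, from the compounds shown here alone, are where compound 3 would stand if it had a number of its own and whether changes elsewhere on the shared core would behave as flatly as those at this position.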